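The compounds below may be only part of what the source reports. "The series", "measured", "known", "first", "only" and "open" are said of these compounds alone.

Of the compounds shown here, three built on one shared core have been measured in an ADME assay on HaCaT cells (Homo sapiens) for cytotoxicity, read by MTT assay, with a stated time of 72 h; on this read-out lower numbers stand for stronger inhibition and higher numbers for weaker inhibition. Compound 1 `Cc1cc(S(=O)(=O)/N=C(\N)n2nccc2-c2ccccc2)c(SCc2ccccc2Cl)cc1Cl` gives 20000 nM. Compound 2 `Cc1cc(S(=O)(=O)/N=C(\N)n2nccc2-c2ccccc2)c(SCc2ccc(C(F)(F)F)cc2)cc1Cl` gives 19000 nM in this assay. Compound 3 `Cc1cc(S(=O)(=O)/N=C(\N)n2nccc2-c2ccccc2)c(SCc2cccc3ccccc23)cc1Cl` gives 11000 nM in this assay.

Each of these three differs from the others only in the aryl group on a saturated chain carbon bound to a sulfur, and every such exchange left the read-out essentially unchanged: a 1.1-fold lower number from compound 1 to compound 2 (0.02 log units; within the scatter), a 1.8-fold lower number from compound 1 to compound 3 (0.26 log units; within the scatter) and a 1.7-fold lower number from compound 2 to compound 3 (0.24 log units; within the scatter). The number for compound 3 sits at the low end of the three, yet its separations from compound 2 and from compound 1 both fall within the scatter, so no ordering among them can be claimed.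

Compound 4 `Cc1ccc(CSc2cc(Cl)c(C)cc2S(=O)(=O)/N=C(\N)n2nccc2-c2ccccc2)cc1` continues this series with one further exchange at the same position: 4-methylphenyl in place of naphthalen-1-yl on a saturated chain carbon bound to a sulfur. The three steps already seen all bear on this change, since each of them swaps one aryl group for another at the same saturated chain carbon, and each stayed within the scatter. On that basis the step of a 1.4-fold higher number from compound 3 to compound 4 (0.13 log units; within the scatter) is expected to be small, with no direction beyond the scatter. Compound 4 is therefore estimated to give 15000 nM in this assay, within a range from 7000 nM to 32000 nM.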

Compound 4, half-maximal inhibitory concentration: 20000 nM
The estimate for compound 4 lay 1.3-fold (0.12 log units) below the measured number; low and high end bracket the measured number.
By their numbers in this assay, from the lowest: compounds 3, 2, 1 and 4 (each within the scatter of the next).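

Giving up a whole aromatic ring at this position, with naphthalen-1-yl leaving and 4-methylphenyl entering, yields a 1.8-fold higher number from compound 3 to compound 4 (0.26 log units; within the scatter) in this assay and so stays within the scatter, even though the group drops from 10 heavy atoms to 7. The new compound also extends the aryl groups at this saturated chain carbon to one carrying only a methyl: methyl in place of trifluoromethyl on an aromatic carbon gives a 1.1-fold higher number from compound 2 to compound 4 (0.02 log units; within the scatter) and 4-methylphenyl in place of 2-chlorophenyl gives no change at the digits printed from compound 1 to compound 4 (within the scatter) in the same read-out, so all the exchanges among these four compounds remain within the scatter. Nothing is available here that would account for this lack of separation.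

Going by these compounds, all four compounds carry an aryl group on this carbon, so it remains open whether an amine, a carboxylic acid or a longer chain in its place would give a number outside the scatter of these values. The compounds also vary only at this one position, which leaves open what an exchange elsewhere on the shared core would do in this assay.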